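This account rests on a few compounds, and the source may have more. Where it says the series, first, only, none or still open, it means among the compounds named here.

The series consists of dichloroacetanilides carrying one substituent on the ring. Compound 1 `Cc1ccccc1NC(=O)C(Cl)Cl` and compound 2 `O=C(Nc1ccccc1F)C(Cl)Cl` have no number in a functional assay on Bel-7402 cells (Homo sapiens) for antiproliferative activity, read by MTT assay, with a stated time of 72 h; a higher number here means a weaker inhibitor, a lower number a stronger inhibitor: for compound 1 the entry reads "not determined" (no result reported), and for compound 2 it reads "not determined" (no result reported). For the measured compounds named here, compound 3 `O=C(Nc1ccccc1Br)C(Cl)Cl` is the only member with a result; in this assay compound 3 gives 38200 nM, so it stands as the sole reference point, a weak inhibitor with nothing else to compare against. Compound 4 `O=C(Nc1ccccc1[N+](=O)[O-])C(Cl)Cl` is the next member: nitro in place of bromo on an aromatic carbon. Going by the values given here, no step between two measured compounds is available, so there is nothing to anchor the size of this change. With a single weak value behind it, the expectation is that compound 4 lands close to compound 3 and that the expected step of a 1.0-fold higher number from compound 3 to compound 4 (0.02 log units; within the scatter) stays within the usual scatter, in either direction. Compound 4 is therefore estimated at about 40000 nM, with a range from 12000 nM to 130000 nM. Because compound 3 gives 38200 nM, a reading for compound 4 that again points to weak inhibition would not be surprising.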

Compound 4, half-maximal inhibitory concentration: 194000 nM
The estimate for compound 4 lay 4.9-fold (0.69 log units) below the measured number; measured number above the stated range.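

In this assay the position proves sensitive to the group it carries: a 5.1-fold higher number from compound 3 to compound 4 (0.71 log units; beyond the scatter) with nitro in place of bromo on the aromatic carbon ortho to a group of 6 heavy atoms, a step beyond the scatter and towards weaker inhibition. Of the two groups with numbers, bromo goes with the lower number, although this rests on a single pair. Nothing at hand accounts for the difference between the two groups.

Steps involving compound 1 or compound 2 cannot be read, so the methyl and fluoro members add nothing to this comparison. As far as these compounds go, how an amine, a carboxylic acid or a methoxy group on the same carbon would read against compound 3 remains open, as does the effect of a longer chain there.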